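The source may hold more compounds than are shown below. What is called first, only, known or untested is meant among the compounds shown, and "the series" means these compounds.

Measured in a functional assay on MGC-803 cells (Homo sapiens) for inhibition, read by CCK-8 assay, with a stated time of 48 h; a lower number here means a stronger inhibitor, a higher number a weaker inhibitor:
- Compound 1 `COc1ccc(CN(C(=O)CSC(=S)N2CCOCC2)c2cc(OC)c(OC)c(OC)c2)cc1`: 2370 nM
- Compound 2 `COc1ccc(CN(C(=O)CSC(=S)N2CCCC2)c2cc(OC)c(OC)c(OC)c2)cc1`: > 20000 nM (a limit)
- Compound 3 `COc1ccc(CN(C(=O)CSC(=S)N2CCN(C(=O)OC(C)(C)C)CC2)c2cc(OC)c(OC)c(OC)c2)cc1OC`: > 20000 nM (a limit)

Compound 3 has no numerical value and rests at the limit of > 20000 nM in this assay, at which 2 of the 3 values shown sit. Compound 4 `COc1ccc(CN(C(=O)CSC(=S)N2CCN(C(=O)OC(C)(C)C)CC2)c2cc(OC)c(OC)c(OC)c2)cc1N` differs from it in one place: amino in place of methoxy on an aromatic carbon. Amino replaces methoxy on an aromatic carbon, so that 3,4-dimethoxybenzyl becomes 3-amino-4-methoxybenzyl.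

For the measured compounds named here, no measured step covers this change. The only one available, an at least 8.4-fold higher number from compound 1 to compound 2 (0.92 log units; beyond the scatter), comes from a different part of the molecule, where pyrrolidin-1-yl replaces morpholin-4-yl on a thiocarbonyl carbon. It bears on the present case only by showing that one substitution can separate a measurable value from the limit in this assay. On that weak basis, a move toward a lower number is expected, although compound 4 could also remain at the limit. The expected change is an at least 2.5-fold lower number from compound 3 to compound 4 (0.39 log units; beyond the scatter). For compound 4, the estimated value is 8000 nM, with an expected range from 1000 nM to 30000 nM.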

Compound 4, half-maximal inhibitory concentration: 184 nM
Compound 4: middle estimate off by 43-fold (1.64 log units), on the high side, and the stated range ends above it.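

On the 3,4-dimethoxybenzyl group, amino in place of methoxy gives an at least 100-fold lower number from compound 3 to compound 4 (2.03 log units; beyond the scatter) in this assay, a large step at a position where no earlier comparison had shown any effect. The value of compound 3 is a limit and not a number, leaving the true size of the step unknown: the limit of > 20000 nM in this assay, at which 2 of the 4 values shown sit. For the compounds shown here, the only earlier step lay at the thiocarbonyl carbon, whereas this one shows that the aromatic carbon ortho to a methoxy group and meta to a large group can also separate a measurable value from the limit.

The compounds shown leave open whether amino is specifically needed at this carbon, or whether a hydroxyl, a dimethylamino or an acetamide group would serve as well. They also leave open whether the 3-amino-4-methoxybenzyl group would give a similar result with morpholin-4-yl or pyrrolidin-1-yl on the thiocarbonyl carbon.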